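Methyl for chlorophenyl on a fused pyrazolo core

A few compounds are considered here, and "the series" means these few. Any claim that something is new, unique, unknown or untested is made for them only; others in the source may bear on it.

Compounds measured so far:
compound 1, `Cc1ccc(-c2c(S(=O)(=O)c3ccccc3)cnc3cc(C)nn23)cc1`, 8.7%
compound 2, `O=S(=O)(c1ccccc1)c1cnc2cc(-c3ccc(Cl)cc3)nn2c1-c1ccc(Br)cc1`, 13.2%
compound 3, `O=S(=O)(c1ccccc1)c1cnc2ncnn2c1-c1ccc(Br)cc1`, 0.9%

In a functional assay on the whole organism for inhibition, with Mus musculus as the target, with a stated time of 6 h, at a dose of 50 mg/kg by the oral route (a lower number here means less inhibition, a higher number more inhibition at the dose given (going by the name of the read-out)), compound 2 gives the highest of the three numbers, yet compound 1 lies within the usual scatter of it, while compound 3 sits beyond the scatter, lower. All three numbers are small.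

Compound 4, `Cc1cc2ncc(S(=O)(=O)c3ccccc3)c(-c3ccc(Br)cc3)n2n1`, has not yet been measured. It differs from compound 2 in one place: methyl in place of 4-chlorophenyl on an aromatic carbon. Among the measured compounds shown here, no step between measured compounds matches this change. Compound 1, which also carries a methyl at that place, gives a number within the scatter of compound 2, so the step of a number 5.2 percentage points lower from compound 2 to compound 4 (within the scatter) is expected to be small, downward at most, and not clearly beyond the scatter. Compound 4 is therefore expected to give about 8%, in the range 0% to 18%.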

Compound 4, a percentage reported as inhibition, in the whole organism at one dose (the size of the read-out at that dose, not a potency): 0%
Estimate against measurement, compound 4: 8 percentage points above; low and high end bracket the measured number.
By their numbers in this assay, from the lowest: compounds 4, 3, 1 and 2 (each within the scatter of the next, the first and the last beyond it).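

In this assay, among the compounds shown here, methyl in place of 4-chlorophenyl at this place gives a number 13.2 percentage points lower from compound 2 to compound 4 (beyond the scatter), the first sign that the group here matters at this dose, though all the numbers remain small. Bromo in place of methyl on an aromatic carbon gives a number 8.7 percentage points lower from compound 1 to compound 4 (within the scatter), so that change shows no clear effect. Nothing measured here explains the step at this place. Going by these compounds, it remains open whether an amine, a carboxylic acid or a longer chain at this place would keep the number of compound 2 or exceed it.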